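Anilinoquinazoline thioethers against prostate cancer cells: the next step

The source may report more compounds than this note shows. Statements on the series, on what has been measured and on what is new or still open speak of the compounds shown alone.

The measured compounds:
compound 1, `Cc1ccccc1Nc1nc(SCc2ccc(C(F)(F)F)cc2)nc2ccccc12`, 36900 nM
compound 2, `FC(F)(F)c1ccc(CSc2nc(Nc3cccc(Cl)c3)c3ccccc3n2)cc1`, 13400 nM
compound 3, `FC(F)(F)c1ccc(CSc2nc(Nc3ccc(C(F)(F)F)cc3)c3ccccc3n2)cc1`, 7880 nM

Three compounds share a core and differ only in the aryl group on the aromatic nitrogen. In a functional assay on PC-3 cells (Homo sapiens) for cytotoxicity, read by MTT assay, with a stated time of 72 h (a lower number here means a stronger inhibitor, a higher number a weaker inhibitor), compound 1 gives 36900 nM, compound 2 gives 13400 nM and compound 3 gives 7880 nM. Compound 3 stands at the low end of these numbers: a 4.7-fold lower number from compound 1 to compound 3 (0.67 log units; beyond the scatter) is beyond the scatter, while a 1.7-fold lower number from compound 2 to compound 3 (0.23 log units; within the scatter) is within it, so compound 3 and compound 2 cannot be told apart. The step of a 2.8-fold lower number from compound 1 to compound 2 (0.44 log units; beyond the scatter) is modest.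

Compound 4, `Fc1ccc(Nc2nc(SCc3ccc(C(F)(F)F)cc3)nc3ccccc23)cc1Cl`, carries the change (3-chloro-4-fluorophenyl in place of 4-(trifluoromethyl)phenyl on a nitrogen on an aromatic ring). The step from compound 2 to compound 3 bears most on it, since compound 2 already holds a chlorine on that ring and sits within the scatter of compound 3. A small move, if any, is therefore expected in this assay, toward a somewhat higher number, as a 1.3-fold higher number from compound 3 to compound 4 (0.12 log units; within the scatter). Compound 4 is estimated at 10500 nM, between 4500 nM and 25000 nM.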

Compound 4, half-maximal inhibitory concentration: 18600 nM
For compound 4 the middle estimate is 1.8-fold (0.25 log units) below the measured one, and the stated range covers the measured number.
By their numbers in this assay, from the lowest: compounds 3, 2, 4 and 1 (each within the scatter of the next, the first and the last beyond it).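

In this assay the change gives a 2.4-fold higher number from compound 3 to compound 4 (0.37 log units; beyond the scatter), so compound 4 can be told apart from compound 3, which compound 2, the other compound with a chlorine on this ring, could not. Even so, the fluoro in place of hydrogen on an aromatic carbon cannot be credited with that separation: a 1.4-fold higher number from compound 2 to compound 4 (0.14 log units; within the scatter), and so compound 2 and compound 4 cannot be told apart. The other end of the series also blurs, for a 2.0-fold lower number from compound 1 to compound 4 (0.30 log units; within the scatter), whereas compound 2 stood clear of compound 1, so at this place the 3-chloro-4-fluorophenyl group cannot be separated from the 2-methylphenyl group, and the four compounds form a shallow run of overlapping values rather than clear tiers.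

Going by these compounds, whether an aryl group on this nitrogen carrying a carboxylic acid, an amine or a methoxy group would fall outside this narrow run remains open, as does what a change elsewhere on the shared core would do. Nothing measured here accounts for the differences among these compounds.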